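Notes on the step from compound 2 to compound 3

A few compounds are considered here, and "the series" means these few. Any claim that something is new, unique, unknown or untested is made for them only; others in the source may bear on it.

- Compound 1 `C=CS(=O)(=O)NC/C=C/c1cc(OC)cc(O)c1C(=O)OCC1CCCCC1`: 5860 nM
- Compound 2 `C=CS(=O)(=O)NC/C=C/c1cc(OC)cc(O)c1C(=O)OCC(C)c1ccccc1`: 7730 nM

In a functional assay on MV4-11 cells (Homo sapiens) for antiproliferative activity, read by luminescence, with a stated time of 72 h (on this read-out lower numbers stand for stronger inhibition and higher numbers for weaker inhibition), compound 2 gives 7730 nM, which cannot be told apart from compound 1 at 5860 nM. Compound 3 `C=CS(=O)(=O)NC/C=C/c1cc(OC)cc(O)c1C(=O)OCc1ccc(F)cc1` is not yet measured. It carries 4-fluorophenyl in place of 1-phenylethyl on a saturated chain carbon bound to an oxygen next to a carbonyl group.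

For the measured compounds named here, one measured step bears on this change: a 1.3-fold higher number from compound 1 to compound 2 (0.12 log units; within the scatter), with 1-phenylethyl in place of cyclohexyl at the same place. Going by the values given here, no measured compound carries 4-fluorophenyl, so this guide is thin. Going by compound 2 and a 1.3-fold higher number from compound 1 to compound 2 (0.12 log units; within the scatter), no step beyond the scatter is expected in this assay, and no direction can be favoured. The estimated step is a 1.2-fold lower number from compound 2 to compound 3 (0.08 log units; within the scatter). The expected value for compound 3 is 6500 nM, with an estimated range from 2500 nM to 15000 nM.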

Compound 3, half-maximal inhibitory concentration: 5140 nM
The estimate for compound 3 lay 1.3-fold (0.10 log units) above the measured number, within the range that was stated.
By their numbers in this assay, from the lowest: compounds 3, 1 and 2 (each within the scatter of the next).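

In this assay, 4-fluorophenyl in place of 1-phenylethyl on a saturated chain carbon bound to an oxygen next to a carbonyl group gives a 1.5-fold lower number from compound 2 to compound 3 (0.18 log units; within the scatter) and 4-fluorophenyl in place of cyclohexyl gives a 1.1-fold lower number from compound 1 to compound 3 (0.06 log units; within the scatter) at the same place. Across compounds 1, 2 and 3, a saturated ring, a branched group bearing a phenyl ring and a fluorinated aromatic ring therefore cannot be told apart, and a fluorine-bearing group now joins the two earlier ones with no step beyond the scatter. No evidence is at hand that would explain this flat result.

From the compounds shown here alone, whether an amine, a carboxylic acid or a longer chain at this place would produce a step beyond the scatter remains open. Also open, going by these compounds, is what the fluorine of 4-fluorophenyl contributes, which would need a comparison with plain phenyl at the same place.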